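Replacing 4-butoxyphenyl with 3-chlorophenyl in compound 3

The source may report more compounds than this note shows. Statements on the series, on what has been measured and on what is new or still open speak of the compounds shown alone.

Measured so far in a functional assay on SGC-7901 cells (Homo sapiens) for antiproliferative activity, read by MTT assay, with a stated time of 24 h; on this read-out lower numbers stand for stronger inhibition and higher numbers for weaker inhibition
- Compound 1 `Cc1ccccc1NNC(=O)c1ccccc1NS(=O)(=O)c1cnc(O)nc1O` gives > 20000 nM (a limit)
- Compound 2 `O=C(NNc1cccc(Cl)c1)c1ccccc1NS(=O)(=O)c1cnc(O)nc1O` gives 10800 nM
- Compound 3 `CCCCOc1ccc(C(=O)NNC(=O)c2ccccc2NS(=O)(=O)c2cnc(O)nc2O)cc1` gives 6890 nM

In this assay compound 3 gives 6890 nM and compound 2 gives 10800 nM as a value within the scatter of it, so these two numbers stand level. For compound 1 the result > 20000 nM is a limit and not a number.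

Compound 4 `O=C(NNC(=O)c1ccccc1NS(=O)(=O)c1cnc(O)nc1O)c1cccc(Cl)c1` is still to be measured. It carries 3-chlorophenyl in place of 4-butoxyphenyl on a carbonyl carbon and the rest of compound 3 stays as it is. Among the compounds with values here, the only measured step that comes near this change is an at least 1.8-fold lower number from compound 1 to compound 2 (0.26 log units; that floor lies within the scatter) and its size is only a floor. Within the data shown here, in that step 3-chlorophenyl enters on an amine nitrogen, not on a carbonyl carbon, and no measured step removes 4-butoxyphenyl. The evidence is therefore indirect. With compound 2 at 10800 nM carrying 3-chlorophenyl, no step beyond the scatter is expected, though the number may drift slightly upward. The expected change is a 1.3-fold higher number from compound 3 to compound 4 (0.12 log units; within the scatter) in this estimate. The estimated value for compound 4 is 9000 nM within an expected range of 3800 nM to 21000 nM.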

Compound 4, half-maximal inhibitory concentration: 1820 nM
Estimate against measurement, compound 4: 4.9-fold (0.69 log units) above; measured number below the stated range.
By their numbers in this assay, from the lowest: compound 4; then compounds 3 and 2 (each within the scatter of the next). At a limit, above all of these: compound 1.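

In this assay, within the data shown here, the group on the carbonyl carbon proves to matter: 3-chlorophenyl in place of 4-butoxyphenyl gives a 3.8-fold lower number from compound 3 to compound 4 (0.58 log units; beyond the scatter), the first step here that rests on two numbers and lies beyond the scatter. The carbonyl also counts, since (3-chlorophenyl)carbonyl in place of 3-chlorophenyl on an amine nitrogen gives a 5.9-fold lower number from compound 2 to compound 4 (0.77 log units; beyond the scatter), so the same aryl group reads very differently depending on where it is attached. Against compound 1, (3-chlorophenyl)carbonyl in place of 2-methylphenyl on an amine nitrogen gives an at least 10-fold lower number from compound 1 to compound 4 (1.04 log units; beyond the scatter), and this size is only a floor, as the result for compound 1 is a limit and not a number: the limit of > 20000 nM in this assay, at which 1 of the 4 values shown sits.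

The compounds shown leave open whether a plain phenyl, a fluorophenyl or a shorter alkoxy chain on that carbonyl carbon would read like compound 4 or like compound 3. Also open, going by these compounds, are how 4-butoxyphenyl would read on an amine nitrogen and whether these steps would hold in another cell line.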